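The compounds below may be only part of what the source reports. "The series", "measured", "known", "first", "only" and "open" are said of these compounds alone.

Compound 2 `CNc1cccc2c(S(=O)(=O)Nc3onc(C)c3C)cccc12` gives 130 nM in an assay on VSM-A10 cells for antagonist activity at Endothelin-1 receptor (Rattus norvegicus) (a higher number here means a weaker inhibitor, a lower number a stronger inhibitor), the lowest of the two numbers at hand. For the measured compounds named here, its only neighbour, compound 1 `Cc1noc(NS(=O)(=O)c2cccc3c(NCc4ccccc4)cccc23)c1C`, gives 590 nM in this assay, and the single measured step is a 4.5-fold lower number from compound 1 to compound 2 (0.66 log units; beyond the scatter). Compound 3 `Cc1noc(NS(=O)(=O)c2cccc3c(N4CCCC4=O)cccc23)c1C` differs from compound 2 by 2-oxopyrrolidin-1-yl in place of methylamino on an aromatic carbon. The measured step changed what the amino nitrogen carries; this change exchanges the amino group itself, so that step bears on it only loosely. A modest rise in number is expected, a 3.1-fold higher number from compound 2 to compound 3 (0.49 log units; beyond the scatter). Compound 3 is therefore estimated at 400 nM, with a range of 100 nM to 1600 nM.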

Compound 3, half-maximal inhibitory concentration: 130 nM
For compound 3 the middle estimate is 3.1-fold (0.49 log units) above the measured one, within the range that was stated.
By their numbers in this assay, from the lowest: compounds 2 and 3 (each within the scatter of the next); then compound 1.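

In this assay, exchanging the amino group itself gives no change at the digits printed from compound 2 to compound 3 (within the scatter), so on this aromatic carbon a ring with 0 hydrogen-bond donors serves as well as methylamino, and the donor of methylamino is not needed for this value. Set against the benzylamino group, the same ring gives a 4.5-fold lower number from compound 1 to compound 3 (0.66 log units; beyond the scatter), so a larger group is not in itself penalised here. No measurement given here explains this result. From the compounds shown here alone, what pyrrolidin-1-yl, which lacks the carbonyl, or a carboxylic acid would give on this aromatic carbon stays open.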